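Series notes: ester side-chain swap from compound 3 to compound 4

The source may hold more compounds than are shown below. What is called first, only, known or untested is meant among the compounds shown, and "the series" means these compounds.

The shared core carries a chlorophenyl group and a chloro substituent; the side chain and the substituent on the ring nitrogen vary. In an ADME assay on HepG2 2.2.15 cells (Homo sapiens) for cytotoxicity (on this read-out higher numbers stand for lower toxicity in this test and lower numbers for higher toxicity in this test), compound 1 `O=c1c(CCO)c(-c2ccccc2Cl)c2cc(Cl)ccc2n1-c1ccccc1` gives 26000 nM. Compound 2 `O=c1c(CCO)c(-c2ccccc2Cl)c2cc(Cl)ccc2n1-c1c(F)cccc1F` reaches only the limit of this assay, > 2300000 nM. The step of an at least 88-fold higher number from compound 1 to compound 2 (1.94 log units; beyond the scatter) is therefore large, with the higher end set by the limit (the limit of > 2300000 nM in this assay, at which 1 of the 3 values shown sits). Compound 3 `CCOCC(=O)OCCc1c(-c2ccccc2Cl)c2cc(Cl)ccc2[nH]c1=O` gives 130000 nM in this assay, the highest of the two numbers shown, with compound 1 the nearest and lower.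

Compound 4 `O=C(/C=C/c1ccccc1)OCCc1c(-c2ccccc2Cl)c2cc(Cl)ccc2[nH]c1=O` differs from compound 3 by 2-phenylethenyl in place of ethoxymethyl on a carbonyl carbon. Within the data shown here, the only measured step changes the substituent on the aromatic nitrogen, not the group on the carbonyl carbon, so no measured step bears directly on this change, and no step beyond the scatter is expected in either direction. Compound 4 is expected at 100000 nM, between 30000 nM and 350000 nM. The expected step is then a 1.3-fold lower number from compound 3 to compound 4 (0.11 log units; within the scatter).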

Compound 4, half-maximal cytotoxic concentration: 230000 nM
Estimate against measurement, compound 4: 2.3-fold (0.36 log units) below; measured number inside the range.
By their numbers in this assay, from the lowest: compound 1; then compounds 3 and 4 (each within the scatter of the next). At a limit, above all of these: compound 2.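

In this assay, among these compounds, the step of a 1.8-fold higher number from compound 3 to compound 4 (0.25 log units; within the scatter) is the first read at this carbonyl carbon, as the only earlier step concerned the group on the aromatic nitrogen. Going from ethoxymethyl, with 4 heavy atoms, to 2-phenylethenyl, with 8 heavy atoms and a six-membered aromatic ring, therefore leaves the read-out within the scatter, so this change shows no separation between the two esters. Nothing on hand accounts for this step.

On these data alone, whether an amine or a carboxylic acid on this carbonyl carbon would also stay within the scatter of compound 3 remains open. Also open is how either ester side chain would read with a 2,6-difluorophenyl on the aromatic nitrogen, since the esters shown carry no group there.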